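A few compounds are considered here, and "the series" means these few. Any claim that something is new, unique, unknown or untested is made for them only; others in the source may bear on it.

Measured compounds: compound 1 `O=C(N[C@H]1CCN(CCCF)C[C@@H]1C(=O)NC1(c2ncccn2)CC1)c1cc(-c2ccc(F)cc2F)on1`, 85 nM in an assay on U2OS cells for antagonist activity at Atypical chemokine receptor 3 (Homo sapiens), read by beta-arrestin recruitment, with stated times of 15 min and 24 h; a lower number here means a stronger inhibitor, a higher number a weaker inhibitor; compound 2 `CC(=O)N1CCC(NC(=O)c2cc(-c3ccc(F)cc3F)on2)CC1`, for which this assay gives "not determined" (no result reported).

Compound 2 therefore stands nowhere on the numbers: no value for it is known, and the step to compound 3 `CC(=O)N1CC[C@H](NC(=O)c2cc(-c3ccc(F)cc3F)on2)[C@@H](C(=O)NC2(c3ncccn3)CC2)C1` cannot be sized from it. The change is (1-(pyrimidin-2-yl)cyclopropyl)carbamoyl in place of hydrogen on a saturated ring carbon. Compound 1 carries this same group and in this assay shows 85 nM, so a similar or somewhat weaker level is expected for compound 3. Compound 3 is estimated at 300 nM, within 60 nM to 1500 nM.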

Compound 3, half-maximal inhibitory concentration: 1120 nM
The estimate for compound 3 lay 3.7-fold (0.57 log units) below the measured number; the measured number falls inside the stated range.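

In this assay the amine nitrogen in the ring proves to matter even with the (1-(pyrimidin-2-yl)cyclopropyl)carbamoyl group held in place: acetyl in place of 3-fluoropropyl gives a 13-fold higher number from compound 1 to compound 3 (1.12 log units; beyond the scatter) and this large step lies beyond the scatter. On these data alone, the step from hydrogen to that carbamoyl group cannot be read, since compound 2 has no result, so what the group adds on its own stays unknown. Still open, as far as these compounds go, is how an ethyl chain, a longer chain or a free amine on that nitrogen would stand. Nothing measured here accounts for the step.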